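Methylsulfanyl for hydroxy on the shared core

A few compounds are considered here, and "the series" means these few. Any claim that something is new, unique, unknown or untested is made for them only; others in the source may bear on it.

Compound 3 `Cc1ncn2c(O)nncc12` stands at the limit of a functional assay for inhibition, with Homo sapiens as the target; on this read-out lower numbers stand for stronger inhibition and higher numbers for weaker inhibition: in this assay compound 3 gives > 48000 nM, a limit rather than a number. Compound 1 `CNc1nncc2c(C)ncn12` gives > 48000 nM, also a limit. Compound 2 `CCCc1ncn2c(SC)nncc12` gives > 48000 nM, again a limit. Among the compounds with values here, the only measured step, a step that the two limits leave unreadable from compound 1 to compound 3, is therefore unreadable (the limit of > 48000 nM in this assay, at which 3 of the 3 values shown sit). Compound 4 `CSc1nncc2c(C)ncn12` differs from compound 3 in one place: methylsulfanyl in place of hydroxy on an aromatic carbon. No readable measured step bears on this change; compound 2, which carries the same methylsulfanyl on the shared core, shows only a limit, as do all three measured compounds. Compound 4 is therefore expected to remain at the limit, the expected step being a step that the limit leaves unreadable from compound 3 to compound 4. The estimate for compound 4 is 100000 nM, within 30000 nM to 400000 nM.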

Compound 4, half-maximal inhibitory concentration: > 48000 nM
Compound 4: a limit, no number; the forecaster's own chance of this, stated with the estimate: 85%; the middle value lies beyond the limit too.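

Compound 4 gives only a limit, so its steps from compound 1, compound 2 and compound 3 cannot be read: the limit of > 48000 nM in this assay, at which 4 of the 4 values shown sit.

The compounds shown leave open which change on the shared core, if any, would bring a readable inhibition.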